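Amide acyl replacement: compound 4 in the series

The source may hold more compounds than are shown below. What is called first, only, known or untested is meant among the compounds shown, and "the series" means these compounds.

For the measured compounds named here, compound 1 `CCC/C=C/C(=O)N(Cc1ccc(OC)c(O)c1)c1cc(OC)c(OC)c(OC)c1` gives 57 nM in a functional assay on KYSE-450 cells (Homo sapiens) for inhibition, read by MTT assay, with a stated time of 48 h (a lower number here means a stronger inhibitor, a higher number a weaker inhibitor), the lowest of the three numbers measured so far. Compound 3 `COc1ccc(CNc2cc(OC)c(OC)c(OC)c2)cc1` gives 4890 nM and is the nearest to it, while compound 2 `COc1ccc(CNc2cc(OC)c(OC)c(OC)c2)cc1C` gives 73800 nM and is the furthest away. Going by the values given here, the one single-point step available, a 15-fold lower number from compound 2 to compound 3 (1.18 log units; beyond the scatter), concerns the ring bearing the methoxy group and not the amide side of the shared core, so it does not bear directly on the change now at hand. Compound 4 `COc1ccc(CN(C(=O)C[Se]C#N)c2cc(OC)c(OC)c(OC)c2)cc1O` differs from compound 1 in a group of 4 heavy atoms (2 carbon, 1 nitrogen, 1 selenium; no ring) in place of a group of 5 heavy atoms (5 carbon; no ring), on a carbonyl carbon. Among the compounds with values here, no measured pair varies the group on the carbonyl carbon; compounds 2 and 3 carry no acyl group at all, and their far higher numbers than compound 1 show only that the acylated compound is the stronger one here. The size of the step to compound 4 is therefore expected to be uncertain, most likely a modest weakening. For compound 4 the estimated value in this assay is 120 nM, within a range of 25 nM to 600 nM. The expected step is a 2.1-fold higher number from compound 1 to compound 4 (0.32 log units; beyond the scatter).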

Compound 4, half-maximal inhibitory concentration: 280 nM
For compound 4 the middle estimate is 2.3-fold (0.37 log units) below the measured one; low and high end bracket the measured number.
By their numbers in this assay, from the lowest: compound 1; then compound 4; then compound 3; then compound 2.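

In this assay the group on the carbonyl carbon now has a measured effect: the selenium-containing nitrile group in place of pent-1-en-1-yl gives a 4.9-fold higher number from compound 1 to compound 4 (0.69 log units; beyond the scatter). The position therefore responds to the identity of the acyl group, yet a group this different from pent-1-en-1-yl, with selenium and a triple bond entering, costs only a modest step. No supporting data bear on the reason for this step.

The compounds shown do not separate the contribution of the selenium atom from that of the nitrile, or either of these from the loss of the pent-1-en-1-yl double bond. A sulfur atom in place of selenium, or a saturated pentyl chain on the carbonyl carbon, would address these open points.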